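Trimethoxybenzophenone cinnamamides: para substituent swap on the styryl ring

A few compounds are considered here, and "the series" means these few. Any claim that something is new, unique, unknown or untested is made for them only; others in the source may bear on it.

Within the data shown here, compound 2 `COc1ccc(C(=O)c2cc(OC)c(OC)c(OC)c2)cc1NC(=O)/C=C/c1ccc(F)cc1` gives 3400 nM in a functional assay on COLO 205 cells (Homo sapiens) for cytotoxicity, read by MTT assay, with a stated time of 72 h (on this read-out lower numbers stand for stronger inhibition and higher numbers for weaker inhibition), and shows the lowest of the two numbers measured so far; its nearest neighbour, compound 1 `COc1cccc(/C=C/C(=O)Nc2cc(C(=O)c3cc(OC)c(OC)c(OC)c3)ccc2OC)c1`, gives 5100 nM in this assay, and the step of a 1.5-fold lower number from compound 1 to compound 2 (0.18 log units; within the scatter) lies within the scatter, so no order between the two is established. Compound 3 `COc1ccc(C(=O)c2cc(OC)c(OC)c(OC)c2)cc1NC(=O)/C=C/c1ccc([N+](=O)[O-])cc1` is not yet measured. It differs from compound 2 by nitro in place of fluoro on an aromatic carbon, the 4-fluorophenyl becoming a 4-nitrophenyl on the ethenyl chain. Among the measured compounds shown here, no measured step touches this exact change; the only step available, a 1.5-fold lower number from compound 1 to compound 2 (0.18 log units; within the scatter), concerns a different pair of groups and was itself small. No basis exists for expecting a shift beyond the scatter, and compound 3 is estimated at 3000 nM in this assay, between 1000 nM and 9000 nM. The expected step is therefore a 1.1-fold lower number from compound 2 to compound 3 (0.05 log units; within the scatter).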

Compound 3, half-maximal inhibitory concentration: 11400 nM
The estimate for compound 3 lay 3.8-fold (0.58 log units) below the measured number; the measured number lies above the stated range.
By their numbers in this assay, from the lowest: compounds 2 and 1 (each within the scatter of the next); then compound 3.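

In this assay, among these compounds, the group on this aromatic carbon of the ethenyl chain's ring now matters: nitro in place of fluoro gives a 3.4-fold higher number from compound 2 to compound 3 (0.53 log units; beyond the scatter) and is the first single change to reach beyond the scatter. The 4-nitrophenyl also stands apart from the 3-methoxyphenyl, with a 2.2-fold higher number from compound 1 to compound 3 (0.35 log units; beyond the scatter) as a modest step, whereas compound 1 and compound 2 could not be put in order. No available data explain why nitro and fluoro differ here.

As far as these compounds go, it remains open whether this loss is specific to nitro or would also appear with an amine or a carboxylic acid on the same aromatic carbon. The compounds shown also leave open whether any group at this position can give a number clearly lower than compound 2 does.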